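A Fluoro Swap on the Ring of Compound 1

The compounds below may be only part of what the source reports. "The series", "measured", "known", "first", "only" and "open" are said of these compounds alone.

Measured in a functional assay on HeLa cells (Homo sapiens) for cytotoxicity, read by MTT assay, with a stated time of 72 h, tested at 10 uM; a higher number here means more inhibition of growth at the concentration tested, a lower number less inhibition of growth:
Compound 1 `N/C(=N\NC(=S)N1CCCCCC1)c1ccccn1`: 67.4%
Compound 2 `Cc1ccnc(/C(N)=N/NC(=S)N2CCCCCC2)c1`: 55.8%
Compound 3 `Cc1cccc(/C(N)=N/NC(=S)N2CCCCCC2)n1`: 71.7%

Compound 1 stands second highest of the three numbers. The step of a number 4.3 percentage points higher from compound 1 to compound 3 (within the scatter) stays within the scatter, so compound 1 and compound 3 cannot be told apart, whereas the step of a number 11.6 percentage points lower from compound 1 to compound 2 (beyond the scatter) lies beyond it.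

Compound 4 `N/C(=N\NC(=S)N1CCCCCC1)c1ccc(F)cn1` differs from compound 1 by fluoro in place of hydrogen on an aromatic carbon, on an aromatic carbon of a six-membered aromatic ring with 1 nitrogen, two atoms from the ring nitrogen and para to a large group. The two measured steps both put a methyl on that ring, not a fluoro, and they point in opposite directions: one modest drop beyond the scatter, one change within it. Neither sits at the same position as the new fluoro, so they give no clear direction, only a sense that single small changes on this ring move the number modestly at most.

Compound 4 is therefore expected to give about 64%, between 50% and 78%. The step of a number 3.4 percentage points lower from compound 1 to compound 4 (within the scatter) is expected to stay within the scatter.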

Compound 4, percent growth inhibition at one concentration: 83.2%
Estimate against measurement, compound 4: 19.2 percentage points below, outside the stated range (above it).
By their numbers in this assay, from the lowest: compound 2; then compounds 1 and 3 (each within the scatter of the next); then compound 4.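

Fluoro in place of hydrogen, on an aromatic carbon two atoms from the ring nitrogen and para to a large group, gives a number 15.8 percentage points higher from compound 1 to compound 4 (beyond the scatter) in this assay. A change of one heavy atom on this ring can therefore raise the number beyond the scatter, which the two methyl steps did not show: one was a number 11.6 percentage points lower from compound 1 to compound 2 (beyond the scatter) and the other was a number 4.3 percentage points higher from compound 1 to compound 3 (within the scatter). No measurement shown here accounts for the rise, so its cause remains unknown.

On these data alone, whether the rise belongs to fluoro itself or would come with other groups at this place stays open, and a chloro, methoxy or trifluoromethyl group there would help to separate the two. As far as these compounds go, it is also open whether a methyl at this same place would follow the fluoro, and whether fluoro on the other ring carbons would give a similar step.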